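The compounds below may be only part of what the source reports. "The series", "measured", "known", "first", "only" and "open" are said of these compounds alone.

Working notes on the series. In a functional assay on HCT-116 cells (Homo sapiens) for inhibition, read by MTT assay, with a stated time of 72 h (on this read-out higher numbers stand for weaker inhibition of growth and lower numbers for stronger inhibition of growth), compound 3 `O[C@H](COCCOC[C@@H](O)Cc1cn(Cc2ccc(C(F)(F)F)cc2)nn1)Cc1ccc(-c2ccccc2)cc1` gives 2500 nM, the lowest of the three numbers recorded so far. Compound 1 `O[C@H](COCCOC[C@@H](O)Cc1cn(Cc2ccc(Oc3ccccc3)cc2)nn1)Cc1ccc(-c2ccccc2)cc1` gives 3400 nM in this assay. Compound 2 `O[C@H](COCCOC[C@@H](O)Cc1cn(-c2cccs2)nn1)Cc1ccc(-c2ccccc2)cc1` gives 33400 nM in this assay. The step of a 1.4-fold lower number from compound 1 to compound 3 (0.13 log units; within the scatter) lies within the scatter, so compound 3 and compound 1 cannot be ordered against each other; the step of a 13-fold lower number from compound 2 to compound 3 (1.13 log units; beyond the scatter) lies beyond it.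

Compound 4 `N#Cc1ccc(Cn2cc(C[C@H](O)COCCOC[C@@H](O)Cc3ccc(-c4ccccc4)cc3)nn2)cc1` has not yet been measured. Relative to compound 3 the change is cyano in place of trifluoromethyl on an aromatic carbon. Of the measured steps, a 1.4-fold lower number from compound 1 to compound 3 (0.13 log units; within the scatter) bears most directly on this change: it exchanges a group at the same aromatic carbon of the same ring and stays within the scatter. The step of a 13-fold lower number from compound 2 to compound 3 (1.13 log units; beyond the scatter) concerns the group on the aromatic nitrogen, which compound 4 keeps as a substituted benzyl, and so bears only indirectly. On this basis no step beyond the scatter is expected in this assay for compound 4, in either direction. The step expected for compound 4 is a 1.2-fold higher number from compound 3 to compound 4 (0.08 log units; within the scatter). Compound 4 is therefore estimated at 3000 nM in this assay, with an expected range from 1200 nM to 7500 nM.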

Compound 4, concentration for 50% growth inhibition: 8800 nM
Beside the measured number, compound 4's estimate is 2.9-fold (0.47 log units) below it; measured number outside the range, above it.
By their numbers in this assay, from the lowest: compounds 3 and 1 (each within the scatter of the next); then compound 4; then compound 2.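

In this assay, the aromatic carbon para to a large group on the benzyl ring now shows that it is not indifferent to its substituent: a 3.5-fold higher number from compound 3 to compound 4 (0.55 log units; beyond the scatter), and a 2.6-fold higher number from compound 1 to compound 4 (0.41 log units; beyond the scatter), whereas trifluoromethyl and phenoxy at this carbon could not be ordered against each other. Cyano is thus the only one of the three groups at this carbon that separates from the others, and it does so towards weaker inhibition of growth. The 4-cyanobenzyl group still holds an advantage over thiophen-2-yl on the aromatic nitrogen, with a 3.8-fold lower number from compound 2 to compound 4 (0.58 log units; beyond the scatter), though this is a smaller step than a 13-fold lower number from compound 2 to compound 3 (1.13 log units; beyond the scatter), and no measurement in hand accounts for the difference between cyano and the other two groups.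

With only trifluoromethyl, phenoxy and cyano at this carbon, the compounds shown leave open where a chlorine, a methoxy, an amine or a carboxylic acid would fall. Also open, as far as these compounds go, is what the benzyl methylene contributes, since compound 2 differs from the others in both ring and linker and a plain phenyl on the aromatic nitrogen is not among them.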